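One More Chloro on a Fast-Disappearing Compound

The source may report more compounds than this note shows. Statements on the series, on what has been measured and on what is new or still open speak of the compounds shown alone.

In an ADME assay on a cell-free system (serum) for metabolic stability (a lower number here means that the compound disappears faster, a higher number that the compound lasts longer), compound 1 (`CC(C)(C)c1cc(OC(=O)c2ccc(Cl)cc2Cl)ccc1O`) gives 0.167 h. From the compounds shown here alone, compound 2 (`CC(C)(C)c1cc(OC(=O)c2ccc([N+](=O)[O-])cc2Cl)ccc1O`) gives < 0.25 h, which is a limit of the assay and not a number, so its true half-life remains unknown.

Compound 3 (`CC(C)(C)c1cc(OC(=O)c2c(Cl)cc([N+](=O)[O-])cc2Cl)ccc1O`) is built from compound 2 by one structural change: chloro in place of hydrogen on an aromatic carbon. A chloro replaces a hydrogen on an aromatic carbon, and the new group sits ortho to a large group, meta to a chloro group and meta to a nitro group.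

For the measured compounds named here, the only measured step, a step that the limit leaves unreadable from compound 1 to compound 2, offers no size to carry over because of the limit of < 0.25 h in this assay, at which 1 of the 2 values shown sits. The expectation therefore rests on little. With compound 1 at 0.167 h, the measured half-lives start short, so more room lies upward than downward in this assay, and a rise is expected, though its size is very uncertain. The expected change is an at least 4.0-fold higher number from compound 2 to compound 3 (0.60 log units; beyond the scatter). For compound 3, the half-life is estimated at 1 h, within a range from 0.15 h to 6 h.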

Compound 3, half-life: < 0.25 h
Compound 3: only a limit was reported; the forecaster's own chance of this, stated with the estimate: 30%; at least 4.0-fold (0.60 log units) between middle value and limit.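

In this assay compound 3 gives < 0.25 h, a limit of the assay and not a number. The step between compound 2 and compound 3 therefore cannot be read, because both compounds end at the same limit: the limit of < 0.25 h in this assay, at which 2 of the 3 values shown sit. The compounds shown leave open how long compound 2 and compound 3 truly last, and whether the added chloro changes that at all.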